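Replacing a Heptyl Chain with Phenyl on the Core

The compounds below may be only part of what the source reports. "The series", "measured", "known", "first", "only" and "open" are said of these compounds alone.

The measured compounds are:
compound 1 `CCSCCn1c(N2CCN(C)CC2)nc2ccccc21` with 19 nM in a functional assay on ileum for inhibition of histamine H1 receptor (Cavia porcellus); a higher number here means a weaker inhibitor, a lower number a stronger inhibitor;
compound 2 `CCCOCCn1c(N2CCN(C)CC2)nc2ccccc21` with 20 nM in this assay;
compound 3 `CCCCCCCn1c(N2CCN(C)CC2)nc2ccccc21` with 150 nM in this assay.

Compound 3 has the highest number of the three, as the steps of a 7.9-fold higher number from compound 1 to compound 3 (0.90 log units; beyond the scatter) and a 7.5-fold higher number from compound 2 to compound 3 (0.88 log units; beyond the scatter) show, while the step of a 1.1-fold higher number from compound 1 to compound 2 (0.02 log units; within the scatter) is within the scatter. Compound 4 `CN1CCN(c2nc3ccccc3n2-c2ccccc2)CC1` arises from compound 3 by the change (phenyl in place of heptyl on an aromatic nitrogen). Within the data shown here, no measured step swaps a chain for an aromatic ring, so the two steps toward compound 3 give only a rough guide: they show that the chain region can move the number by a modest amount. Compound 4 is therefore expected to come out with a step of a 2.5-fold lower number from compound 3 to compound 4 (0.40 log units; beyond the scatter), giving an estimated 60 nM with a range from 15 nM to 250 nM.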

Compound 4, half-maximal inhibitory concentration: 760 nM
Compound 4: middle estimate off by 13-fold (1.10 log units), on the low side; measured number above the stated range.
By their numbers in this assay, from the lowest: compounds 1 and 2 (each within the scatter of the next); then compound 3; then compound 4.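

On the aromatic nitrogen, an aromatic ring does worse than any of the three chains: phenyl in place of heptyl gives a 5.1-fold higher number from compound 3 to compound 4 (0.70 log units; beyond the scatter) in this assay. The loss is larger against the chains that carry sulfur or oxygen, with a 40-fold higher number from compound 1 to compound 4 (1.60 log units; beyond the scatter) and a 38-fold higher number from compound 2 to compound 4 (1.58 log units; beyond the scatter). No evidence at hand explains this loss.

As far as these compounds go, it remains open whether the drop belongs to the ring itself or to the ring sitting directly on the nitrogen. A benzyl or 2-phenylethyl group at this position would help separate these two readings.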